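Swapping a Carbon Ring for an Oxygen-Containing Ring

A few compounds are considered here, and "the series" means these few. Any claim that something is new, unique, unknown or untested is made for them only; others in the source may bear on it.

Of the compounds shown here, three that share one core have been measured in an assay on cells for binding affinity to Neuropeptide Y receptor type 1 (Homo sapiens); a higher number here means a weaker inhibitor, a lower number a stronger inhibitor. Compound 1 `CCc1sc(CCc2cc(OC(C)C)cc(NCc3cc(Cl)cc(NC(=O)OC(C)C)c3)n2)nc1C` gives 12 nM, compound 2 `CCc1sc(CCc2cc(OCC3(C)CC3)cc(NCc3cc(Cl)cc(NC(=O)OC(C)C)c3)n2)nc1C` gives 17 nM, and compound 3 `CCc1sc(CCc2cc(OC3CCCCC3)cc(NCc3cc(Cl)cc(NC(=O)OC(C)C)c3)n2)nc1C` gives 29 nM. Compound 3 has the highest number of the three; the two steps that end at it are a 1.7-fold higher number from compound 2 to compound 3 (0.23 log units; within the scatter) and a 2.4-fold higher number from compound 1 to compound 3 (0.38 log units; beyond the scatter).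

Compound 4 `CCc1sc(CCc2cc(OC3CCOCC3)cc(NCc3cc(Cl)cc(NC(=O)OC(C)C)c3)n2)nc1C` is a further variation at the same position. The change is oxan-4-yl in place of cyclohexyl on an oxygen on an aromatic ring. All three measured steps alter the group on this oxygen, and each was small: a 1.4-fold higher number from compound 1 to compound 2 (0.15 log units; within the scatter), a 2.4-fold higher number from compound 1 to compound 3 (0.38 log units; beyond the scatter) and a 1.7-fold higher number from compound 2 to compound 3 (0.23 log units; within the scatter). Among the measured compounds shown here, none of them exchanges a ring carbon for a ring oxygen, so there is no direct precedent; what the measured set shows is that changes of this kind at this place have moved this assay only modestly. An expected step of a 1.2-fold higher number from compound 3 to compound 4 (0.08 log units; within the scatter) therefore seems reasonable, with no strong direction. Compound 4 is estimated to give 35 nM, within a range from 15 nM to 85 nM.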

Compound 4, half-maximal inhibitory concentration: 4.4 nM
For compound 4 the middle estimate is 8.0-fold (0.90 log units) above the measured one, and the stated range ends above it.
By their numbers in this assay, from the lowest: compound 4; then compounds 1, 2 and 3 (each within the scatter of the next, the first and the last beyond it).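

In this assay, exchanging a ring carbon for a ring oxygen gives a 6.6-fold lower number from compound 3 to compound 4 (0.82 log units; beyond the scatter) even though cyclohexyl and oxan-4-yl have the same ring size and the same heavy-atom count, so this position responds to more than the size of the group on the oxygen. The other comparisons, a 3.9-fold lower number from compound 2 to compound 4 (0.59 log units; beyond the scatter) and a 2.7-fold lower number from compound 1 to compound 4 (0.44 log units; beyond the scatter), both favour oxan-4-yl as well, which makes compound 4 the strongest inhibitor of the four, while compound 3, its all-carbon counterpart, has the highest number. No measurement shown here explains why this single atom exchange has such an effect.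

The compounds shown leave open whether the gain depends on where the oxygen sits in the ring, as oxan-3-yl would test, and whether a smaller ring such as oxetan-3-yl would also keep it. They also leave open whether a ring nitrogen, as in piperidin-4-yl, or an open chain such as 2-methoxyethyl could take the place of oxan-4-yl.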